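From methoxy to ethoxycarbonyl on an aromatic carbon

The source may report more compounds than this note shows. Statements on the series, on what has been measured and on what is new or still open speak of the compounds shown alone.

Compound 1 `COc1ccc(S(=O)(=O)NC(C2=CC(=O)c3c(O)ccc(O)c3C2=O)C(C)C)cc1`: 8950 nM
Compound 2 `CC(=O)c1ccc(S(=O)(=O)NC(C2=CC(=O)c3c(O)ccc(O)c3C2=O)C(C)C)cc1`: 3820 nM

For the measured compounds named here, in a functional assay on HeLa cells (Homo sapiens) for cytotoxicity, read by sulforhodamine B assay (on this read-out higher numbers stand for weaker inhibition and lower numbers for stronger inhibition), compound 1 gives 8950 nM, the higher of the two numbers so far, which makes it the weaker inhibitor of the pair. Compound 3 `CCOC(=O)c1ccc(S(=O)(=O)NC(C2=CC(=O)c3c(O)ccc(O)c3C2=O)C(C)C)cc1` keeps the core of compound 1 and changes one group: ethoxycarbonyl in place of methoxy on an aromatic carbon, para to a large group (ethoxycarbonyl in place of methoxy on an aromatic carbon). Going by the values given here, the one measured step that bears on this is acetyl in place of methoxy on an aromatic carbon, a modest change: a 2.3-fold lower number from compound 1 to compound 2 (0.37 log units; beyond the scatter). A single step is thin evidence, but a similarly modest move towards a lower number is expected in this assay. The expected step is a 2.2-fold lower number from compound 1 to compound 3 (0.35 log units; beyond the scatter). For compound 3 the estimate is 4000 nM, with an expected range of 1700 nM to 9500 nM.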

Compound 3, half-maximal inhibitory concentration: 850 nM
The estimate for compound 3 lay 4.7-fold (0.67 log units) above the measured number, and the stated range ends above it.
By their numbers in this assay, from the lowest: compound 3; then compound 2; then compound 1.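

Ethoxycarbonyl in place of methoxy gives an 11-fold lower number from compound 1 to compound 3 (1.02 log units; beyond the scatter), well beyond what acetyl achieved, and replacing only the methyl of the acetyl with ethoxy still gives a 4.5-fold lower number from compound 2 to compound 3 (0.65 log units; beyond the scatter). Acetyl and ethoxycarbonyl both carry a carbonyl on this aromatic carbon, so a carbonyl alone does not set the number here: what is attached to it matters too. Nothing measured here says why this is so.

Going by these compounds, how a carboxylic acid, an amide or a longer chain such as butoxycarbonyl would read at this position remains open.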